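Hydroxy to carboxy: one swap repeated on a second core

A few compounds are considered here, and "the series" means these few. Any claim that something is new, unique, unknown or untested is made for them only; others in the source may bear on it.

Measured compounds:
- compound 1, `CCOc1ccc2nc(C(=O)Nc3c(F)cc(-c4cccc(F)c4)cc3F)c(C)c(O)c2c1`, gives 15.3% in a functional assay on A-375 cells (Homo sapiens) for antiproliferative activity, read by MTT assay, with a stated time of 24 h, tested at 11.11 ug/mL; on this read-out lower numbers stand for a weaker effect and higher numbers for a stronger effect at the one concentration tested
- compound 2, `COc1ccc2nc(C(=O)Nc3ccc(-c4ccccc4)cc3)c(C)c(O)c2c1`, gives 36.2% in this assay
- compound 3, `CCOc1ccc2nc(C(=O)Nc3c(F)cc(-c4cccc(F)c4)cc3F)c(C)c(C(=O)O)c2c1`, gives 48.3% in this assay

Among the compounds with values here, the one step that can be followed directly is from compound 1 to compound 3, where the change is carboxy in place of hydroxy on an aromatic carbon. The step it made in this assay is a number 33 percentage points higher from compound 1 to compound 3 (beyond the scatter). Among the three measured compounds, compound 2 stands second; its nearest neighbour is compound 3, and compound 1 lies furthest from it, both gaps beyond the scatter. How the core of compound 2 differs from that of compound 1 is not broken down here.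

Compound 4, `COc1ccc2nc(C(=O)Nc3ccc(-c4ccccc4)cc3)c(C)c(C(=O)O)c2c1`, has not been measured in this assay. It differs from compound 2 by carboxy in place of hydroxy on an aromatic carbon; the place is described word for word as for the change from compound 1 to compound 3, so this is the same change, now made on the core of compound 2.

Within the data shown here, only one earlier example of the step exists, on a different core, so its size may not carry over fully. Still, a step of the same direction is expected from compound 2 to compound 4 in this assay, estimated at a number 21.8 percentage points higher from compound 2 to compound 4 (beyond the scatter), because compound 1 to compound 3 gave a number 33 percentage points higher from compound 1 to compound 3 (beyond the scatter). Compound 4 is expected to give about 58%, with a likely range from 35% to 80%.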

Compound 4, a percentage reported as inhibition, at one concentration (the size of the read-out at that concentration, not a potency): 47.9%
Compound 4: the middle estimate sits 10.1 percentage points above what was measured; low and high end bracket the measured number.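

In this assay, carboxy in place of hydroxy on the core of compound 2 gives a number 11.7 percentage points higher from compound 2 to compound 4 (beyond the scatter), so the direction seen on the core of compound 1 recurs on a second core in this series. The size of the step does not carry over from one core to the other, and a step read on one core gives only its direction, not a reliable size, for the other: the same change on two cores in this assay, a number 33 percentage points higher (beyond the scatter) from compound 1 to compound 3 and a number 11.7 percentage points higher (beyond the scatter) from compound 2 to compound 4, 21.3 percentage points apart, beyond the scatter of two such steps These two pairs do not show which difference between the cores goes with the smaller step, since compound 1 and compound 2 differ in more than one place, and a read-out at one concentration gives the size of the effect there, not a potency.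

The compounds shown leave open whether the rise is tied to carboxy itself, as they hold no other group at this place on the six-membered aromatic ring with 1 nitrogen, such as an amine or a methyl ester. They also leave open how the step behaves on further cores, for example with a longer chain in place of the ethoxy or methoxy group, or with only some of the fluorines of compound 1 kept.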